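Substituent at the fused-ring position in the urea series

The source may hold more compounds than are shown below. What is called first, only, known or untested is meant among the compounds shown, and "the series" means these compounds.

Measured so far in a functional assay on MDA-MB-231 cells (Homo sapiens) for cytotoxicity, read by MTT assay, with a stated time of 72 h; on this read-out lower numbers stand for stronger inhibition and higher numbers for weaker inhibition:
compound 1 `O=C(Nc1ccc(-n2ncc3c(Cl)cccc32)cc1)Nc1ccc(Cl)c(C(F)(F)F)c1` gives 1600 nM
compound 2 `Cc1cccc2c1cnn2-c1ccc(NC(=O)Nc2ccc(Cl)c(C(F)(F)F)c2)cc1` gives 2300 nM
compound 3 `O=C(Nc1ccc(-n2ncc3ccccc32)cc1)Nc1ccc(Cl)c(C(F)(F)F)c1` gives 5000 nM

Compound 3 carries no substituent on the fused carbocyclic ring and stands highest of the three numbers. The step of a 3.1-fold higher number from compound 1 to compound 3 (0.49 log units; beyond the scatter) replaces chloro with hydrogen at that carbon, and the step of a 2.2-fold higher number from compound 2 to compound 3 (0.34 log units; beyond the scatter) replaces methyl with hydrogen at the same carbon; both lie beyond the scatter, both modest. The step of a 1.4-fold higher number from compound 1 to compound 2 (0.16 log units; within the scatter) between the two substituted compounds stays within the scatter, so chloro and methyl cannot be ordered against each other here.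

Compound 4 `CNc1cccc2c1cnn2-c1ccc(NC(=O)Nc2ccc(Cl)c(C(F)(F)F)c2)cc1` differs from compound 3 by methylamino in place of hydrogen on an aromatic carbon. Nothing measured tells how a methylamino group behaves at this site; the only bearing is that two different groups at the same carbon, chloro and methyl, each gave a lower number than hydrogen. On that basis a modest lowering in this assay is expected for compound 4, of roughly the size seen with methyl, as a 2.0-fold lower number from compound 3 to compound 4 (0.30 log units; within the scatter). Compound 4 is estimated at 2500 nM, with a range from 1000 nM to 6000 nM.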

Compound 4, half-maximal inhibitory concentration: 3600 nM
Compound 4: middle estimate off by 1.4-fold (0.16 log units), on the low side; low and high end bracket the measured number.
By their numbers in this assay, from the lowest: compounds 1, 2, 4 and 3 (each within the scatter of the next, the first and the last beyond it).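

In this assay, among these compounds, methylamino is the first group on this aromatic carbon that does not separate from hydrogen, since the step of a 1.4-fold lower number from compound 3 to compound 4 (0.14 log units; within the scatter) stays within the scatter, whereas chloro and methyl each stood beyond it against hydrogen; a substituent at this carbon therefore does not by itself bring a difference from the unsubstituted compound, and compounds 1 and 2 show one while compound 4 does not. Methylamino also cannot be told from methyl, given the step of a 1.6-fold higher number from compound 2 to compound 4 (0.19 log units; within the scatter) within the scatter, and only chloro separates from it, modestly, with the step of a 2.3-fold higher number from compound 1 to compound 4 (0.35 log units; beyond the scatter) lying beyond the scatter. Nothing available accounts for methylamino behaving differently from chloro at this carbon.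

Still open, on these data alone, is whether the nitrogen matters at all here, which a plain amine or a dimethylamino group at the same carbon would address, and whether an oxygen-linked group such as methoxy would fall with chloro or with hydrogen. A longer chain on the nitrogen, or a carboxylic acid at this carbon, would show how far the small differences seen so far extend, with the rest of the core left unchanged.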